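The source may hold more compounds than are shown below. What is called first, only, known or untested is meant among the compounds shown, and "the series" means these compounds.

Measured so far:
compound 1, `C[C@@H](NC(=O)c1ccc(C#Cc2cccc(F)c2)cn1)C(C)(C)C`, efficacy 66%
compound 2, `C[C@H](NC(=O)c1ccc(C#Cc2cccc(F)c2)cn1)C(C)(C)C`, efficacy 70.8%
compound 3, `CCCNC(=O)c1ccc(C#Cc2cccc(F)c2)cn1`, efficacy 65.9%

In a functional assay on HEK293 cells for positive allosteric modulation of metabotropic glutamate receptor 5 (Rattus norvegicus), read by fluorescence and calcium flux (a lower number here means a smaller maximal response, a higher number a larger maximal response), compound 1 gives 66%, compound 2 gives 70.8% and compound 3 gives 65.9%. All three numbers lie within the scatter of one another: the step from compound 1 to compound 2 is a number 4.8 percentage points higher from compound 1 to compound 2 (within the scatter), and the two amide substituents compared in the steps of a number 0.1 percentage points lower from compound 1 to compound 3 (within the scatter) and a number 4.9 percentage points lower from compound 2 to compound 3 (within the scatter) leave the maximal response unchanged. Compound 3 thus holds the lowest of the three numbers, but its nearest neighbour, compound 1, sits within a fraction of a point, and even compound 2 is within the scatter.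

Compound 4, `CC(C)CNC(=O)c1ccc(C#Cc2cccc(F)c2)cn1`, is not yet measured. It differs from compound 3 as methyl in place of hydrogen on a saturated chain carbon bound to two saturated chain carbons. Among the measured compounds shown here, the steps that bear on it are those on the same amide nitrogen: propyl in place of 1,2,2-trimethylpropyl gave a number 0.1 percentage points lower from compound 1 to compound 3 (within the scatter) and a number 4.9 percentage points lower from compound 2 to compound 3 (within the scatter), both within the scatter, so a much larger change of branching at that nitrogen did not move the maximal response. A single methyl added on the chain of compound 3 is a smaller change than either of those. No step beyond the scatter is therefore expected in this assay; the expected step from compound 3 to compound 4 is a number 1.1 percentage points higher from compound 3 to compound 4 (within the scatter). Compound 4 is estimated at 67%, within a range from 57% to 78%.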

Compound 4, largest response reached (reported as efficacy), in percent of the reference or control that the assay uses: 58.2%
Estimate against measurement, compound 4: 8.8 percentage points above, and the stated range covers the measured number.
By their numbers in this assay, from the lowest: compounds 4, 3, 1 and 2 (each within the scatter of the next, the first and the last beyond it).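

Methyl in place of hydrogen on a saturated chain carbon bound to two saturated chain carbons, which turns propyl into isobutyl, stays within the scatter in this assay (a number 7.7 percentage points lower from compound 3 to compound 4 (within the scatter)). Isobutyl in place of 1,2,2-trimethylpropyl gives the only step beyond the scatter among these compounds, and a modest one (a number 12.6 percentage points lower from compound 2 to compound 4 (beyond the scatter)), whereas the same replacement starting from compound 1 stays within the scatter (a number 7.8 percentage points lower from compound 1 to compound 4 (within the scatter)). One replacement on the amide nitrogen thus reads differently from two starting compounds that themselves lie within the scatter of each other, and the single difference between them is this: the fact that compounds 1 and 2 differ only in the configuration as drawn.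

The compounds shown leave open whether the maximal response follows any trend in the size or branching of the amide substituent, as the single step beyond the scatter rests on one pair. Also open, from the compounds shown here alone, is how a longer chain such as pentyl, a cyclopropylmethyl group, or a hydroxyl or an amine on the chain would read in this assay.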